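Sulfamoyl carbamates: symmetric dialkyl in place of methyl(octyl)

A few compounds are considered here, and "the series" means these few. Any claim that something is new, unique, unknown or untested is made for them only; others in the source may bear on it.

Three compounds on the shared core have numbers. In an assay on liver for inhibition of sterol O-acyltransferase 1 (Rattus norvegicus), using microsomes (on this read-out higher numbers stand for weaker inhibition and lower numbers for stronger inhibition), compound 1 `CCCCCCNS(=O)(=O)NC(=O)Oc1c(C(C)(C)C)cc(C)cc1C(C)(C)C` gives 19400 nM. Compound 2 `CCCCN(CCCC)S(=O)(=O)NC(=O)Oc1c(C(C)(C)C)cc(C)cc1C(C)(C)C` gives 3200 nM in this assay, and compound 3 `CCCCCCCCN(C)S(=O)(=O)NC(=O)Oc1c(C(C)(C)C)cc(C)cc1C(C)(C)C` gives 18000 nM. Compound 3 stands second highest of the three, within the scatter of compound 1; its separation from the lowest number is a 5.6-fold higher number from compound 2 to compound 3 (0.75 log units; beyond the scatter). Compound 4 `CCCCCN(CCCCC)S(=O)(=O)NC(=O)Oc1c(C(C)(C)C)cc(C)cc1C(C)(C)C` carries dipentylamino in place of methyl(octyl)amino on a sulfonyl sulfur. Within the data shown here, two measured steps bear on this change: hexylamino to dibutylamino, a 6.1-fold lower number from compound 1 to compound 2 (0.78 log units; beyond the scatter), and dibutylamino to methyl(octyl)amino, a 5.6-fold higher number from compound 2 to compound 3 (0.75 log units; beyond the scatter). In both, the symmetric dialkyl member carries the lower number, and dipentylamino is again a symmetric dialkyl arrangement, as dibutylamino is. A lower number is therefore expected for compound 4 in this assay, by about a 5.1-fold lower number from compound 3 to compound 4 (0.71 log units; beyond the scatter). The estimate for compound 4 is 3500 nM, with a range from 1200 nM to 10000 nM.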

Compound 4, half-maximal inhibitory concentration: 2200 nM
Beside the measured number, compound 4's estimate is 1.6-fold (0.20 log units) above it, and the stated range covers the measured number.
By their numbers in this assay, from the lowest: compounds 4 and 2 (each within the scatter of the next); then compounds 3 and 1 (each within the scatter of the next).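

In this assay, a second symmetric dialkyl group on the sulfonyl sulfur sets itself apart from both other arrangements, with an 8.2-fold lower number from compound 3 to compound 4 (0.91 log units; beyond the scatter) and an 8.8-fold lower number from compound 1 to compound 4 (0.95 log units; beyond the scatter), so the link between symmetric dialkyl groups and the lower numbers now rests on two compounds, and none of the four goes against it. Dipentylamino in place of dibutylamino gives a 1.5-fold lower number from compound 2 to compound 4 (0.16 log units; within the scatter), so this pair of symmetric chains shows no separable effect of chain length. No measurement at hand accounts for these differences.

Dipropylamino and dihexylamino would show how far the symmetric series holds at shorter and longer chains. An unsymmetric butyl(pentyl)amino group would test whether symmetry itself matters, or whether two chains of similar length are enough.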